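Swapping the aryl group of compound 1 for 4-fluorophenyl

The source may report more compounds than this note shows. Statements on the series, on what has been measured and on what is new or still open speak of the compounds shown alone.

In a functional assay on Caco-2 cells (Homo sapiens) for cytotoxicity, with a stated time of 48 h (on this read-out lower numbers stand for stronger inhibition and higher numbers for weaker inhibition), compound 1 `COc1cc(OC)c(C(=O)/C=C/c2ccccc2SC)c(OC)c1` gives 8800 nM, and compound 3 `COc1cc(OC)c(C(=O)/C=C/c2ccccc2)c(OC)c1` stands level with it at 5800 nM. Compound 2 `COc1cccc(/C=C/C(=O)c2c(OC)cc(OC)cc2OC)c1` gives 3900 nM, so compound 1 stands above it, with a 2.3-fold lower number from compound 1 to compound 2 (0.35 log units; beyond the scatter). Compound 4 `COc1cc(OC)c(C(=O)/C=C/c2ccc(F)cc2)c(OC)c1` differs from compound 1 as follows: 4-fluorophenyl in place of 2-(methylsulfanyl)phenyl on a double-bonded chain carbon bound to a double-bonded chain carbon. Hydrogen in place of methylsulfanyl gave a 1.5-fold lower number from compound 1 to compound 3 (0.18 log units; within the scatter), and hydrogen in place of methoxy gave a 1.5-fold higher number from compound 2 to compound 3 (0.17 log units; within the scatter). Going by the values given here, no compound with fluorine has been measured, so these steps are the only guide. Only a small move toward lower numbers is expected, with the estimated step being a 1.6-fold lower number from compound 1 to compound 4 (0.20 log units; within the scatter). Compound 4 is estimated at 5500 nM, with an expected range of 2500 nM to 11000 nM.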

Compound 4, half-maximal inhibitory concentration: 5500 nM
Compound 4: middle estimate and measured number agree at the digits printed, and the stated range covers the measured number.
By their numbers in this assay, from the lowest: compounds 2, 4, 3 and 1 (each within the scatter of the next, the first and the last beyond it).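

In this assay, going by these compounds alone, fluoro in place of hydrogen on an aromatic carbon leaves the number unchanged within the scatter (a 1.1-fold lower number from compound 3 to compound 4 (0.02 log units; within the scatter)), which the earlier compounds could not show, as none carried fluorine. 4-Fluorophenyl on this chain carbon is also within the scatter of both 2-(methylsulfanyl)phenyl (a 1.6-fold lower number from compound 1 to compound 4 (0.20 log units; within the scatter)) and 3-methoxyphenyl (a 1.4-fold higher number from compound 2 to compound 4 (0.15 log units; within the scatter)), so it does not separate from either group. No measurement shown here bears on the cause of these small steps. From the compounds shown here alone, whether an amine or a carboxylic acid on this aromatic ring would move the number beyond the scatter remains open.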